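A few compounds are considered here, and "the series" means these few. Any claim that something is new, unique, unknown or untested is made for them only; others in the source may bear on it.

Of the compounds shown here, three built on one shared core have been tested in a functional assay on the whole organism with Mus musculus as the target, in the maximal electroshock model, with a stated time of 1 h; a lower number here means that less compound is needed, a higher number that more compound is needed for the effect. Compound 1 `Cc1ccccc1-c1nnc(N(N)C(C)C)s1` gives 54 mg/kg. Compound 2 `CC(C)N(N)c1nnc(-c2ccccc2Cl)s1` differs from compound 1 by chloro in place of methyl on an aromatic carbon, and in this assay compound 2 gives 54 mg/kg, so that the step is no change at the digits printed from compound 1 to compound 2 (within the scatter). Compound 3 `Cc1ccccc1-c1nnc(NNC(C)C)s1` differs from compound 1 in how the same atoms are joined: (isopropylamino)amino in place of amino(isopropyl)amino on an aromatic carbon. In this assay compound 3 gives 83 mg/kg, a step of a 1.5-fold higher number from compound 1 to compound 3 (0.19 log units; within the scatter). Compound 3 thus has the highest of the three numbers, but its gaps to compound 1 and compound 2 both lie within the scatter, so no order among them can be read.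

Compound 4 `CC(C)NNc1nnc(-c2ccccc2Cl)s1` has not yet been measured in this assay. Within the data shown here, it differs from compound 3 by chloro in place of methyl on an aromatic carbon, which is the same change as the one from compound 1 to compound 2. The expected step is a 1.0-fold lower number from compound 3 to compound 4 (0.02 log units; within the scatter). That expectation rests on the earlier step of no change at the digits printed from compound 1 to compound 2 (within the scatter), which stayed within the scatter. Compound 4 is therefore estimated at 80 mg/kg, with a likely range from 45 mg/kg to 140 mg/kg.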

Compound 4, dose for half-maximal effect: 50 mg/kg
The estimate for compound 4 lay 1.6-fold (0.20 log units) above the measured number; the range from low to high includes it.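

In this assay, chloro in place of methyl gives a 1.7-fold lower number from compound 3 to compound 4 (0.22 log units; within the scatter), and this step can be set directly beside the same change on the other core: the same change on two cores in this assay, no change at the digits printed (within the scatter) from compound 1 to compound 2 and a 1.7-fold lower number (0.22 log units; within the scatter) from compound 3 to compound 4, 1.7-fold (0.22 log units) apart, within the scatter of two such steps. Likewise, (isopropylamino)amino in place of amino(isopropyl)amino gives a 1.1-fold lower number from compound 2 to compound 4 (0.03 log units; within the scatter), and the comparison with its earlier counterpart reads: the same change on two cores in this assay, a 1.5-fold higher number (0.19 log units; within the scatter) from compound 1 to compound 3 and a 1.1-fold lower number (0.03 log units; within the scatter) from compound 2 to compound 4, 1.7-fold (0.22 log units) apart, within the scatter of two such steps. Among these compounds, both changes therefore carry from one core to the other with no readable difference, but every step here lies within the scatter, so this shows only that neither change had a clear effect in these four compounds, not that a large effect would carry over in the same way.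

The compounds shown leave open whether other groups on that aromatic carbon, such as fluoro, methoxy or a carboxylic acid, would give a step beyond the scatter. They also leave open what a longer chain in place of isopropyl would do on either core.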